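Moving the Ring Oxygen in a Weak Receptor Binder

The source may hold more compounds than are shown below. What is called first, only, known or untested is meant among the compounds shown, and "the series" means these compounds.

Compound 1 `CCCOc1cccc2ccc(N)nc12` and compound 2 `Nc1ccc2cccc(OCC3CCCO3)c2n1` share one core and differ only in the group on a saturated chain carbon bound to an oxygen on an aromatic ring. In an assay on cells with melanin-concentrating hormone receptor 1 (Homo sapiens) as the target, read by radioligand binding (on this read-out higher numbers stand for weaker inhibition and lower numbers for stronger inhibition), compound 1 gives 1100 nM. For compound 2 the assay reports only a limit, > 2000 nM. From the compounds shown here alone, the step of an at least 1.8-fold higher number from compound 1 to compound 2 (0.25 log units; that floor lies within the scatter) shows that oxolan-2-yl in place of ethyl brought no gain, but how far compound 2 lies past the limit of > 2000 nM in this assay, at which 1 of the 2 values shown sits, is unknown. Compound 3 `Nc1ccc2cccc(OCC3CCOC3)c2n1` has not been measured. It differs from compound 2 by oxolan-3-yl in place of oxolan-2-yl on a saturated chain carbon bound to an oxygen on an aromatic ring; the atoms are the same and only their joining changes. For the measured compounds named here, no measured step bears directly on shifting the oxygen within this five-membered ring, and the single step of an at least 1.8-fold higher number from compound 1 to compound 2 (0.25 log units; that floor lies within the scatter) only places compound 2 at the limit, so the starting point is itself uncertain. Compound 3 is expected to give about 3000 nM, within 1000 nM and 10000 nM, in this assay. That estimate means a step that the limit leaves unreadable from compound 2 to compound 3, nothing beyond the scatter, with a fair chance that compound 3 is also reported only as a limit.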

Compound 3, half-maximal inhibitory concentration: 115 nM
The estimate for compound 3 lay 26-fold (1.42 log units) above the measured number, outside the stated range (below it).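

In this assay, the place where the five-membered ring is joined matters a great deal: with the same atoms joined differently, oxolan-3-yl in place of oxolan-2-yl gives an at least 17-fold lower number from compound 2 to compound 3 (1.24 log units; beyond the scatter), something the first two compounds could not reveal. Oxolan-3-yl also does better than the plain ethyl group, with a 9.6-fold lower number from compound 1 to compound 3 (0.98 log units; beyond the scatter), so carrying this ring on the chain carbon does not by itself settle the outcome, while the way it is joined makes a clear difference among these three compounds. Compound 2 is reported only as a limit, so the true size of the step from it remains a floor: the limit of > 2000 nM in this assay, at which 1 of the 3 values shown sits.

The compounds shown leave open whether the ring oxygen itself is needed, which a cyclopentyl ring, with carbon in place of that oxygen, or a pyrrolidin-3-yl ring, with an amine nitrogen there, could help to test. They also leave open whether a longer chain carrying the oxolan-3-yl group would keep the number as low.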